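Anilide variation on a curcuminoid chalcone, SiHa cell inhibition

The source may hold more compounds than are shown below. What is called first, only, known or untested is meant among the compounds shown, and "the series" means these compounds.

Measured so far:
Compound 1, `COc1cc(/C=C/C(=O)c2cccc(NC(=O)c3c(Cl)cccc3Cl)c2)ccc1O`, 3.56 ug/mL
Compound 2, `COc1cc(/C=C/C(=O)c2cccc(N)c2)ccc1O`, 12.3 ug/mL
Compound 3, `COc1cc(/C=C/C(=O)c2cccc(NC(=O)c3ccc(Cl)c(Cl)c3)c2)ccc1O`, 25.3 ug/mL

The three measured compounds share one core and differ only at the aromatic nitrogen. In a functional assay on SiHa cells (Homo sapiens) for inhibition (a lower number here means a stronger inhibitor, a higher number a weaker inhibitor), compound 1 gives the lowest of the three numbers; compound 2 is nearest, compound 3 furthest. Removing the acyl group altogether gives a 3.5-fold higher number from compound 1 to compound 2 (0.54 log units; beyond the scatter), and swapping one dichlorophenyl pattern for another gives a 7.1-fold higher number from compound 1 to compound 3 (0.85 log units; beyond the scatter); both steps run the same way and lie beyond the scatter. From compound 2 to compound 3 the number rises again, a 2.1-fold higher number from compound 2 to compound 3 (0.31 log units; beyond the scatter).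

Compound 4, `COC(=O)C(=O)Nc1cccc(C(=O)/C=C/c2ccc(O)c(OC)c2)c1`, is not yet measured. It differs from compound 1 as follows: methoxycarbonyl in place of 2,6-dichlorophenyl on a carbonyl carbon. Going by the values given here, no measured pair tests this particular replacement, so the expectation rests on the two steps away from compound 1, one of which removes the acyl group and one of which alters it, and both of which weaken inhibition by a modest margin. An upward step in this assay is therefore expected for compound 4, of a size near those two steps, a 3.4-fold higher number from compound 1 to compound 4 (0.53 log units; beyond the scatter). The estimated value for compound 4 is 12 ug/mL, with a range from 4 ug/mL to 35 ug/mL.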

Compound 4, half-maximal inhibitory concentration: 7.71 ug/mL
Estimate against measurement, compound 4: 1.6-fold (0.19 log units) above, and the stated range covers the measured number.
By their numbers in this assay, from the lowest: compound 1; then compounds 4 and 2 (each within the scatter of the next); then compound 3.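

Replacing the ring on this carbonyl carbon with methoxycarbonyl leaves the nitrogen acylated, yet the outcome in this assay depends on which ring leaves: the loss of 2,6-dichlorophenyl gives a 2.2-fold higher number from compound 1 to compound 4 (0.34 log units; beyond the scatter) and the loss of 3,4-dichlorophenyl gives a 3.3-fold lower number from compound 3 to compound 4 (0.52 log units; beyond the scatter) as the opposite result. Compound 4 has no ring in this acyl group and still lies on the low side of compound 3, so a dichlorophenyl group on this carbonyl carbon is not needed for a number of this size, and only the 2,6-dichlorophenyl group of compound 1 stands beyond the scatter below compound 4. Acylation of the nitrogen also has no single direction, since (methoxycarbonyl)carbonyl cannot be separated from hydrogen at this position (a 1.6-fold lower number from compound 2 to compound 4 (0.20 log units; within the scatter)), whereas compound 1 and compound 3 lie on opposite sides of compound 2 beyond the scatter.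

The compounds shown leave open where a carboxylic acid in place of methoxycarbonyl, an acetyl group or an unsubstituted phenyl on this carbonyl carbon would fall against compound 1 and compound 2. No measurement shown bears on what lies behind these steps.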